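The source may report more compounds than this note shows. Statements on the series, on what has been measured and on what is new or still open speak of the compounds shown alone.

In a physicochemical assay for lipophilicity, at pH 7.4 (on this read-out higher numbers stand for higher lipophilicity and lower numbers for lower lipophilicity), compound 1 `CN(Cc1ccc2nccn2c1)c1nnc(-c2ccc(-c3ccccc3Cl)nc2)o1` gives 3.3, compound 3 `CNC(=O)c1sc(N2CC3CC2(CNC(=O)c2c[nH]c4ncc(C(F)(F)F)cc24)C3)nc1C(F)(F)F` gives 4.2 and compound 2 `CNc1nc(OC2CCCC2)nc2c1ncn2Cc1c(F)cccc1F` gives 4.3. Compound 2 therefore lies within the usual scatter of compound 3 and beyond the scatter above compound 1. Compound 4 `CNc1nc(OCC2CCC2)nc2c1ncn2Cc1c(F)cccc1F` has not yet been measured. It differs from compound 2 in one place: cyclobutylmethyl in place of cyclopentyl on an oxygen on an aromatic ring, with cyclobutylmethyl in place of cyclopentyl on an oxygen on an aromatic ring. Among the measured compounds shown here, the two compounds have the same atoms, joined differently, and no measured pair shows this kind of swap. The expected move, no change at the digits printed from compound 2 to compound 4 (within the scatter), stays within the scatter and favours neither direction. Compound 4 is estimated at 4.3, with an expected range from 3.9 to 4.7.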

Compound 4, distribution coefficient: 4.4
Estimate against measurement, compound 4: 0.10 log units below, and the stated range covers the measured number.
By their numbers in this assay, from the lowest: compound 1; then compounds 3, 2 and 4 (each within the scatter of the next).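

In this assay, putting cyclobutylmethyl in place of cyclopentyl on an oxygen on an aromatic ring gives a number 0.10 log units higher from compound 2 to compound 4 (within the scatter). At this position, then, rearranging the same 5 carbons from a five-membered ring into a four-membered ring is a change this read-out does not separate. No supporting measurement bears on this outcome.

Still open, as far as these compounds go, is whether a group of a different kind on this oxygen, such as an amine, a carboxylic acid or a longer chain, would move the number beyond the scatter. From the compounds shown here alone, whether the same swap behaves alike on another core is also open.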